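Swapping the amide aryl group: from compound 3 to compound 4

A few compounds are considered here, and "the series" means these few. Any claim that something is new, unique, unknown or untested is made for them only; others in the source may bear on it.

Three compounds share one core and differ only in the aryl group on the carbonyl carbon. In an assay on MDA-MB-231 cells for binding affinity to C-X-C chemokine receptor type 4 (Homo sapiens), read by immunofluorescence and microscopy, with stated times of 10 min and 30 min (a lower number here means that less compound is needed, a higher number that more compound is needed for the effect), compound 1 `O=C(NCc1ccc(CNS(=O)(=O)c2ccccc2)cc1)c1cccc(F)c1` gives 100 nM, compound 2 `O=C(NCc1ccc(CNS(=O)(=O)c2ccccc2)cc1)c1cccnc1` gives 10 nM, and compound 3 `Cc1ccccc1C(=O)NCc1ccc(CNS(=O)(=O)c2ccccc2)cc1` gives 1 nM. Compound 3 stands lowest of the three: its steps are a 100-fold lower number from compound 1 to compound 3 (2.00 log units; beyond the scatter) and a 10-fold lower number from compound 2 to compound 3 (1.00 log units; beyond the scatter), both beyond the scatter.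

Compound 4 `O=C(NCc1ccc(CNS(=O)(=O)c2ccccc2)cc1)c1cccc(Cl)c1` is not yet measured in this assay. It differs from compound 3 in one place: 3-chlorophenyl in place of 2-methylphenyl on a carbonyl carbon.

The step that bears on this change is a 100-fold lower number from compound 1 to compound 3 (2.00 log units; beyond the scatter), since compound 1 also carries a halogen-bearing phenyl, a 3-fluorophenyl, on the same carbonyl carbon. Compound 4 therefore resembles compound 1 more than compound 3, and the step back is expected to run the other way, though a chlorine is not a fluorine and the size is uncertain. The expected step is a 50-fold higher number from compound 3 to compound 4 (1.70 log units; beyond the scatter). Compound 4 is thus estimated at 50 nM, between 10 nM and 300 nM.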

Compound 4, effective concentration (reported as EC, without a stated level of effect): 1000 nM
Compound 4: middle estimate off by 20-fold (1.30 log units), on the low side, and the stated range ends below it.
By their numbers in this assay, from the lowest: compound 3; then compound 2; then compound 1; then compound 4.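

In this assay, the step with chloro in place of fluoro on an aromatic carbon is a 10-fold higher number from compound 1 to compound 4 (1.00 log units; beyond the scatter) and is beyond the scatter, so the two halogen-bearing phenyl groups do not read alike at this position. Placing 3-chlorophenyl on the carbonyl carbon gives a 1000-fold higher number from compound 3 to compound 4 (3.00 log units; beyond the scatter) when it replaces 2-methylphenyl and a 100-fold higher number from compound 2 to compound 4 (2.00 log units; beyond the scatter) when it replaces pyridin-3-yl, which leaves compound 4 with the highest number of the four and makes this the widest span seen at this position. Nothing given here accounts for these differences.

What the compounds shown leave open is whether the low number of compound 3 follows the methyl itself or its place on the ring, a question that 3-methylphenyl and 2-chlorophenyl would help settle. Nor do they tell how an amine or a carboxylic acid on the phenyl would read.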